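A few compounds are considered here, and "the series" means these few. Any claim that something is new, unique, unknown or untested is made for them only; others in the source may bear on it.

Three compounds have been measured in a functional assay on SN12C cells (Homo sapiens) for inhibition, read by sulforhodamine B assay, with a stated time of 48 h; a higher number here means a weaker inhibitor of growth, a lower number a stronger inhibitor of growth:

- compound 1 `O=C(Nc1cccc(-n2cc(-c3ccncc3)c(-c3ccc(Cl)c(O)c3)n2)c1)Nc1cccc(C(F)(F)F)c1`: 2010 nM
- compound 2 `COc1cc(-c2nn(-c3cccc(NC(=O)c4cccc(C(F)(F)F)c4)c3)cc2-c2ccncc2)ccc1Cl`: 3310 nM
- compound 3 `COc1cc(-c2nn(-c3cccc(NC(=O)Nc4cccc(C(F)(F)F)c4)c3)cc2-c2ccncc2)ccc1Cl`: 1400 nM

Compound 2, at 3310 nM, lies within the scatter of compound 1. Its only gap beyond the scatter is a 2.4-fold lower number from compound 2 to compound 3 (0.37 log units; beyond the scatter).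

The next compound is compound 4 `COc1cc(-c2nn(-c3cccc(NC(=O)c4ccc(Cl)c(C(F)(F)F)c4)c3)cc2-c2ccncc2)ccc1Cl`, which has not yet been measured. It differs from compound 2 at one place: chloro in place of hydrogen on an aromatic carbon, ortho to a trifluoromethyl group and para to a large group (chloro in place of hydrogen on an aromatic carbon). The 3-(trifluoromethyl)phenyl thus becomes 4-chloro-3-(trifluoromethyl)phenyl.

Among the measured compounds shown here, no measured step makes this change, so the evidence is only indirect. The methyl in place of hydrogen on an oxygen gives a 1.4-fold lower number from compound 1 to compound 3 (0.16 log units; within the scatter). The change at the carbonyl carbon, in the same part of the molecule as the new chloro, gives a 2.4-fold lower number from compound 2 to compound 3 (0.37 log units; beyond the scatter), which is modest. For the measured compounds named here, since the single changes seen so far are this small, no step beyond the scatter is expected in this assay, and the data fix no direction firmly.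

For compound 4 the estimated value is 2500 nM, with an expected range from 1000 nM to 6000 nM. This estimate means an expected 1.3-fold lower number from compound 2 to compound 4 (0.12 log units; within the scatter).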

Compound 4, concentration for 50% growth inhibition: 11200 nM
Beside the measured number, compound 4's estimate is 4.5-fold (0.65 log units) below it, and the stated range ends below it.
By their numbers in this assay, from the lowest: compounds 3, 1 and 2 (each within the scatter of the next, the first and the last beyond it); then compound 4.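

In this assay, chloro in place of hydrogen on the aromatic carbon ortho to a trifluoromethyl group and para to a large group gives a 3.4-fold higher number from compound 2 to compound 4 (0.53 log units; beyond the scatter), which shows that this position of the 3-(trifluoromethyl)phenyl does not tolerate every change without consequence in growth inhibition. Putting 4-chloro-3-(trifluoromethyl)phenyl in place of (3-(trifluoromethyl)phenyl)amino on the carbonyl carbon gives an 8.0-fold higher number from compound 3 to compound 4 (0.90 log units; beyond the scatter), a wider gap than any among compounds 1, 2 and 3, and compound 4 stands as the weakest inhibitor of growth of the four. No measurement shown here explains why the chloro raises the number.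

The compounds shown leave open whether this rise belongs to chloro in particular or would also follow from a smaller or different group at the same carbon, such as fluoro, methyl, methoxy or an amine. They also leave open whether the same chloro would raise the number when the (3-(trifluoromethyl)phenyl)amino of compound 3 carries it, or when the hydroxy-bearing ring of compound 1 is present.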